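The source may report more compounds than this note shows. Statements on the series, on what has been measured and on what is new or still open speak of the compounds shown alone.

Compound 1 `COc1cccc2cc(C(=O)O)cnc12`: 150 mg/kg
Compound 2 `O=C(O)c1cnc2c(Cl)cccc2c1O`: > 100 mg/kg
Compound 3 `O=C(O)c1cnc2c(C(F)(F)F)cccc2c1`: 75 mg/kg

Of the compounds shown here, three on a shared core have been tested in a functional assay on the whole organism (strain Sprague-Dawley) for inhibition, with Rattus norvegicus as the target; on this read-out higher numbers stand for an effect only at larger amounts of compound and lower numbers for an effect already at smaller amounts. Compound 1 gives 150 mg/kg. Compound 3 gives 75 mg/kg in this assay, the lowest of the two numbers shown. For compound 2 the assay reports only a limit, > 100 mg/kg, and no number. The step from compound 1 to compound 3 is a 2.0-fold lower number from compound 1 to compound 3 (0.30 log units; within the scatter), so these two numbers lie within the scatter of each other and no order between them can be claimed.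

Compound 4 `O=C(O)c1cnc2c(Cl)cccc2c1` has not yet been measured. It differs from compound 3 in one place: chloro in place of trifluoromethyl on an aromatic carbon. Within the data shown here, no measured step swaps trifluoromethyl for chloro. Among the measured compounds shown here, the only step known, a 2.0-fold lower number from compound 1 to compound 3 (0.30 log units; within the scatter), concerned a different exchange and stayed within the scatter. Compound 2 also carries chloro, and for it only the limit of > 100 mg/kg in this assay, at which 1 of the 3 values shown sits, is known, which gives no number to lean on.

With so little to go on, compound 4 is expected to stay close to compound 3, a step of a 1.3-fold higher number from compound 3 to compound 4 (0.12 log units; within the scatter) in this assay. The estimate for compound 4 is 100 mg/kg, with a range from 50 mg/kg to 200 mg/kg.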

Compound 4, minimum effective dose: 150 mg/kg
Beside the measured number, compound 4's estimate is 1.5-fold (0.18 log units) below it, and the stated range covers the measured number.
By their numbers in this assay, from the lowest: compounds 3, 1 and 4 (each within the scatter of the next).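

In this assay, the exchange of trifluoromethyl for chloro on an aromatic carbon ortho to a fused ring now has a measured size: a 2.0-fold higher number from compound 3 to compound 4 (0.30 log units; within the scatter), so no order can be claimed between these two compounds. The exchange of methoxy for chloro at the same place gives no change at the digits printed from compound 1 to compound 4 (within the scatter). Methoxy, trifluoromethyl and chloro have now all been compared in pairs at this position, and each of the three pairs lies within the scatter, so this read-out does not tell these groups apart, even though trifluoromethyl has more heavy atoms than chloro.

Compound 2 has only a limit, so its step to compound 4, which would show what the hydroxy group does, cannot be read: the limit of > 100 mg/kg in this assay, at which 1 of the 4 values shown sits. As far as these compounds go, it remains open whether a different kind of group at this position, such as an amine or a nitrile, would move the dose beyond the scatter, and whether the position matters at all, since the three groups compared here give no difference that can be told from repeat-measurement noise.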